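This account rests on a few compounds, and the source may have more. Where it says the series, first, only, none or still open, it means among the compounds named here.

In an ADME assay on MDBK cells (Bos taurus) for cytotoxicity, read by MTT assay, with a stated time of 96 h (a higher number here means that more compound is tolerated, a lower number that less compound is tolerated), compound 3 (`CC(=O)NC(=S)Nc1cccc(C(F)(F)F)c1`) gives > 100000 nM, which is a limit of the assay and not a number. Compound 4 (`FC(F)(F)c1cccc(NC(=S)Nc2cccc(Br)c2)c1`) carries 3-bromophenyl in place of acetyl on an amide-type nitrogen. Compound 1 (`FC(F)(F)c1cccc(NC(=S)Nc2ccc(I)cc2)c1`), with 4-iodophenyl, gives 9500 nM, and compound 2 (`FC(F)(F)c1cccc(NC(=S)Nc2ccc(Cl)cc2)c1`), with 4-chlorophenyl, gives 17000 nM. The step between these two is a 1.8-fold higher number from compound 1 to compound 2 (0.25 log units; within the scatter). The steps closest to the new change are an at least 10-fold higher number from compound 1 to compound 3 (1.02 log units; beyond the scatter) and an at least 5.8-fold higher number from compound 2 to compound 3 (0.76 log units; beyond the scatter), and each puts acetyl where a substituted phenyl group stood. Compound 4 runs that kind of change in reverse, so a lower number is expected in this assay, with an estimated at least 8.3-fold lower number from compound 3 to compound 4 (0.92 log units; beyond the scatter). Compound 4 is estimated at 12000 nM, with an expected range of 5000 nM to 30000 nM.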

Compound 4, half-maximal cytotoxic concentration: 10000 nM
Compound 4: middle estimate off by 1.2-fold (0.08 log units), on the high side; the measured number falls inside the stated range.
By their numbers in this assay, from the lowest: compounds 1, 4 and 2 (each within the scatter of the next). At a limit, above all of these: compound 3.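

In this assay, a phenyl group with its halogen named at a different ring position still gives an at least 10-fold lower number from compound 3 to compound 4 (1.00 log units; beyond the scatter) when it replaces acetyl. The halogen and its position can change together without a readable shift, with a 1.7-fold lower number from compound 2 to compound 4 (0.23 log units; within the scatter) and a 1.1-fold higher number from compound 1 to compound 4 (0.02 log units; within the scatter), so 3-bromophenyl sits level with 4-chlorophenyl and 4-iodophenyl. Compound 3 remains a limit of the assay and not a number: the limit of > 100000 nM in this assay, at which 1 of the 4 values shown sits.

Still open, from the compounds shown here alone, is what a phenyl group with no halogen would give, or one carrying an amine or a carboxylic acid. Also open, going by these compounds, is whether a longer chain in place of acetyl would stay at such a limit.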